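Tail flick activity of purine glycinamide esters

The source may hold more compounds than are shown below. What is called first, only, known or untested is meant among the compounds shown, and "the series" means these compounds.

Measured compounds:
compound 1, `N=C(N)NCCC[C@H](NC(=O)CN(c1nc(Cl)nc2[nH]cnc12)C1CC1)C(=O)OCc1ccccc1`, 10.2%
compound 2, `CC[C@H](C)[C@H](NC(=O)CN(c1ncnc2c1ncn2C1CCCCO1)C1CC1)C(=O)OCc1ccccc1`, 20.4%

In a functional assay on the whole organism (Tail, strain ICR) with Mus musculus as the target, in the tail flick test, with a stated time of 120 min, at a dose of 25 umol/kg by the oral route (on this read-out lower numbers stand for a weaker effect and higher numbers for a stronger effect at the one dose given), compound 2 gives the higher of the two numbers, and the number for compound 1 stands lower by a gap beyond the scatter. Compound 3, `CC(C)(C)OC(=O)NCCCC[C@H](NC(=O)CN(c1ncnc2c1ncn2C1CCCCO1)C1CC1)C(=O)OCc1ccccc1`, has not yet been measured. It differs from compound 2 in one place: 4-((tert-butoxycarbonyl)amino)butyl in place of sec-butyl on a saturated chain carbon bound to an amide-type nitrogen and a carbonyl carbon. Among the measured compounds shown here, no measured pair shows this change, so the size of its step is open. Compound 3 is expected to give a number close to that of compound 2, with the step of a number 3.4 percentage points lower from compound 2 to compound 3 (within the scatter) estimated to be small and not beyond the scatter. Compound 3 is estimated at 17%, between 2% and 35%.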

Compound 3, a percentage reported as activity, at one dose (the size of the read-out at that dose, not a potency): 28.4%
Compound 3: the middle estimate sits 11.4 percentage points below what was measured; the range from low to high includes it.
By their numbers in this assay, from the lowest: compound 1; then compounds 2 and 3 (each within the scatter of the next).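

In this assay, placing 4-((tert-butoxycarbonyl)amino)butyl instead of sec-butyl on the saturated chain carbon bound to an amide-type nitrogen and a carbonyl carbon gives a number 8 percentage points higher from compound 2 to compound 3 (within the scatter). The read-out therefore does not separate these two groups at this position, although they differ widely in their heavy atoms. No available measurement bears on this result. On these data alone, whether a free amine at the end of the butyl chain, a carboxylic acid or a longer chain would read the same at this position remains open.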